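Swapping an Oxadiazole for an Imidazole on a Urea Core

The source may hold more compounds than are shown below. What is called first, only, known or untested is meant among the compounds shown, and "the series" means these compounds.

Compound 1 `Cc1cc(C)c(NC(=O)N(Cc2ccc(-c3nnc(C)o3)cc2)C2CCCCCC2)c(C)c1`: > 0.32 mg/kg
Compound 2 `Cc1cc(C)c(NC(=O)N(Cc2cccc(-c3cc[nH]n3)c2)C2CCCC2)c(C)c1`: < 1 mg/kg
Compound 3 `O=C(Nc1c(F)cc(F)cc1F)N(Cc1ccc(-n2cccc2)cc1)C1CCCCCC1`: > 1 mg/kg

In a functional assay on a cell-free system (plasma) with sterol O-acyltransferase, Soat (Rattus norvegicus) as the target (on this read-out lower numbers stand for an effect already at smaller amounts and higher numbers for an effect only at larger amounts of compound), compound 1 gives > 0.32 mg/kg, which is a limit of the assay and not a number. In this assay compound 2 gives < 1 mg/kg, again a limit. In this assay compound 3 gives > 1 mg/kg, also a limit. For the measured compounds named here, every value shown is thus a limit (the limit of < 1 mg/kg in this assay, at which 1 of the 3 values shown sits, (the limit of > 0.32 mg/kg in this assay, at which 1 of the 3 values shown sits), (the limit of > 1 mg/kg in this assay, at which 1 of the 3 values shown sits)), so compound 1 cannot be placed against compound 2 or compound 3 beyond the fact that its limit is the lowest of the three, and no step between measured compounds can be sized.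

Compound 4 `Cc1cc(C)c(NC(=O)N(Cc2ccc(-n3ccnc3)cc2)C2CCCCCC2)c(C)c1` differs from compound 1 in one place: 1H-imidazol-1-yl in place of 5-methyl-1,3,4-oxadiazol-2-yl on an aromatic carbon. Going by the values given here, with no measured step to lean on, the change from compound 1 is expected to move the result by no more than the usual scatter, so the step that the limit leaves unreadable from compound 1 to compound 4 is estimated as small. For compound 4 the expected value in this assay is 0.7 mg/kg, within a range from 0.25 mg/kg to 2.5 mg/kg.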

Compound 4, dose for half-maximal effect: > 1 mg/kg
Compound 4: a limit, no number; the forecaster's own chance of this, stated with the estimate: 60%; at least 1.4-fold (0.15 log units) between middle value and limit.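

For the compounds shown here, compound 1 and compound 4 each carry only a limit in this assay, not a number, so no step between them can be read. The compounds shown leave open whether 1H-imidazol-1-yl in place of 5-methyl-1,3,4-oxadiazol-2-yl changes the result at all, and in which direction.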